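Chloro for methyl on a fluorinated nucleotide core

The compounds below may be only part of what the source reports. "The series", "measured", "known", "first", "only" and "open" are said of these compounds alone.

Measured so far:
compound 1 `CC#Cc1cn([C@H]2C[C@H](O)[C@@H](COP(=O)(O)O)O2)c(=O)[nH]c1=O` — > 40000 nM
compound 2 `Cc1cn(COCCOP(=O)(O)O)c(=O)[nH]c1=O` — > 100000 nM
compound 3 `Cc1cn(C2CC(F)C(COP(=O)(O)O)O2)c(=O)[nH]c1=O` — 1500 nM

Among the measured compounds shown here, in a functional assay on liver (Oryctolagus cuniculus) for inhibition (a lower number here means a stronger inhibitor, a higher number a weaker inhibitor), compound 3 gives 1500 nM and is the only compound with a number rather than a limit. For compound 1 the value > 40000 nM is a limit of this assay, not a number. For compound 2 the value > 100000 nM is likewise a limit. Compound 4 `O=c1[nH]c(=O)n(C2CC(F)C(COP(=O)(O)O)O2)cc1Cl` has not yet been measured in this assay. It differs from compound 3 in one place: chloro in place of methyl on an aromatic carbon. For the measured compounds named here, no step between measured compounds is available, so the size of this change can only be expected. The exchange of one heavy atom for another of the same size is expected to move the value by little, within or just beyond the usual scatter, as the step of a 1.7-fold higher number from compound 3 to compound 4 (0.22 log units; within the scatter) means. Compound 4 is therefore estimated at 2500 nM, expected to lie between 800 nM and 8000 nM.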

Compound 4, half-maximal inhibitory concentration: 9000 nM
Estimate against measurement, compound 4: 3.6-fold (0.56 log units) below; the measured number lies above the stated range.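

In this assay, the change brings a 6.0-fold higher number from compound 3 to compound 4 (0.78 log units; beyond the scatter), so this position on the aromatic ring tells methyl and chloro apart even though one heavy atom simply replaces another. On this fluorinated core, compound 3 with its methyl is therefore the stronger inhibitor of the pair. No measurement shown bears on why the exchange has this effect. Still open, as far as these compounds go, is how other groups at this position would behave, such as ethyl, bromo or an amine, and whether the same exchange would have a similar effect on a core carrying hydroxyl in place of fluoro.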